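An aryl swap and what compound 3 should give

This account rests on a few compounds, and the source may have more. Where it says the series, first, only, none or still open, it means among the compounds named here.

Compound 1 `O=c1[nH]cc(S(=O)(=O)Nc2ccc(-c3cn(-c4ccccc4)nn3)cc2)c(=O)[nH]1` gives 18800 nM in a functional assay on SGC-7901 cells (Homo sapiens) for antiproliferative activity, read by MTT assay, with a stated time of 24 h; a lower number here means a stronger inhibitor, a higher number a weaker inhibitor.
Compound 2 `Cc1cccc(-n2cc(-c3ccc(NS(=O)(=O)c4c[nH]c(=O)[nH]c4=O)cc3)nn2)c1` gives 17500 nM in this assay.

Compound 2 holds the lower of the two numbers, yet compound 1 stands within the scatter of it, so no order between the two can be claimed. For the measured compounds named here, the only measured step, a 1.1-fold lower number from compound 1 to compound 2 (0.03 log units; within the scatter), is itself within the scatter. Compound 3 `O=c1[nH]cc(S(=O)(=O)Nc2ccc(-c3cn(-c4ccccc4F)nn3)cc2)c(=O)[nH]1` differs from compound 2 in one place: 2-fluorophenyl in place of 3-methylphenyl on an aromatic nitrogen. Going by the values given here, no measured step bears on this exchange; the one step available concerns a different alteration on a different ring and was small. With nothing pointing in either direction, for compound 3 the expected step is a 1.0-fold higher number from compound 2 to compound 3 (0.01 log units; within the scatter), that is, no change beyond the scatter. On that basis compound 3 is estimated at 18000 nM in this assay, with a range from 8000 nM to 40000 nM.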

Compound 3, half-maximal inhibitory concentration: 7270 nM
Compound 3: the middle estimate sits 2.5-fold (0.39 log units) above what was measured; measured number below the stated range.
By their numbers in this assay, from the lowest: compound 3; then compounds 2 and 1 (each within the scatter of the next).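

The aryl group on the aromatic nitrogen proves to be a place where the number in this assay can move: a single added fluoro gives a 2.6-fold lower number from compound 1 to compound 3 (0.41 log units; beyond the scatter) and stands beyond the scatter, which the methyl step had not. The full exchange of 3-methylphenyl for 2-fluorophenyl gives a 2.4-fold lower number from compound 2 to compound 3 (0.38 log units; beyond the scatter) and is likewise modest, so this ring tolerates more than one substituent and responds to at least one of them. Nothing measured here explains the step.

Fluoro appears only as 2-fluorophenyl and methyl only as 3-methylphenyl, so whether the lower number follows the fluorine itself or where it sits remains open. Also open, as far as these compounds go, is how a chloro, a methoxy or an amine on this ring would read.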